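A few compounds are considered here, and "the series" means these few. Any claim that something is new, unique, unknown or untested is made for them only; others in the source may bear on it.

The measured compounds:
compound 1 `Cc1ccc(-n2nccn2)c(C(=O)N2C[C@@H]3CN(c4nc(C)c(C)c(C)n4)C[C@@H]3C2)c1`, 4850 nM
compound 2 `Cc1ccc(-n2nccn2)c(C(=O)N2C[C@@H]3CN(c4ncnc5ccccc45)C[C@@H]3C2)c1`, 1690 nM
compound 3 `Cc1ccc(-n2nccn2)c(C(=O)N2C[C@@H]3CN(c4nc(-c5cccc(Cl)c5)co4)C[C@@H]3C2)c1`, 2790 nM

These three share one core and differ only in the group on the amine nitrogen of the fused ring. In a functional assay on HEK293 cells for antagonist activity at Orexin receptor type 2 (Homo sapiens), read by FLIPR and calcium flux, with a stated time of 60 min (on this read-out higher numbers stand for weaker inhibition and lower numbers for stronger inhibition), compound 1 gives 4850 nM, the highest of the three numbers. Compound 3 gives 2790 nM, a number within the scatter of compound 1. Compound 2 gives 1690 nM, and the step of a 2.9-fold lower number from compound 1 to compound 2 (0.46 log units; beyond the scatter) is the only one of the set that goes beyond the scatter.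

Compound 4 `Cc1ccc(-n2nccn2)c(C(=O)N2C[C@@H]3CN(c4ncc5cc(F)ccc5n4)C[C@@H]3C2)c1` has not yet been measured. It differs from compound 1 in one place: 6-fluoroquinazolin-2-yl in place of 4,5,6-trimethylpyrimidin-2-yl on an amine nitrogen in a ring. Going by the values given here, the one measured step that bears on this change is a 2.9-fold lower number from compound 1 to compound 2 (0.46 log units; beyond the scatter), where a quinazoline also replaced the trimethylpyrimidine, although compound 2 bears quinazolin-4-yl and compound 4 bears 6-fluoroquinazolin-2-yl. Among the compounds with values here, no measured step covers the fluorine or this second quinazoline attachment on its own.

On that single step a modest lowering of the number is expected, a 2.9-fold lower number from compound 1 to compound 4 (0.46 log units; beyond the scatter), with wide uncertainty. Compound 4 is estimated at 1700 nM, with the expected range from 500 nM to 5500 nM.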

Compound 4, half-maximal inhibitory concentration: 108 nM
Estimate against measurement, compound 4: 16-fold (1.20 log units) above; measured number below the stated range.
By their numbers in this assay, from the lowest: compound 4; then compounds 2, 3 and 1 (each within the scatter of the next, the first and the last beyond it).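

Going by these compounds alone, the group on the amine nitrogen in the ring can move this number much further than the earlier compounds showed: in this assay, 6-fluoroquinazolin-2-yl in place of 4,5,6-trimethylpyrimidin-2-yl gives a 45-fold lower number from compound 1 to compound 4 (1.65 log units; beyond the scatter), whereas the only earlier step beyond the scatter was a 2.9-fold lower number from compound 1 to compound 2 (0.46 log units; beyond the scatter). A quinazoline at this position is not enough on its own to give such a large step, since the two quinazoline groups themselves are separated by a 16-fold lower number from compound 2 to compound 4 (1.19 log units; beyond the scatter), so the outcome here depends on the particular quinazoline group and not just on the presence of one. No measured evidence is available that would explain either step.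

The compounds shown leave open how the step from quinazolin-4-yl to 6-fluoroquinazolin-2-yl divides between the change of attachment and the fluorine, a question that the plain quinazolin-2-yl group would address directly. They also leave open whether the fluorine can be exchanged, for instance in 6-chloroquinazolin-2-yl or 6-methoxyquinazolin-2-yl, with the number staying as low as that of compound 4.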